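Ester to Acid on Two Cores, Tolerability Unchanged

A few compounds are considered here, and "the series" means these few. Any claim that something is new, unique, unknown or untested is made for them only; others in the source may bear on it.

Compound 1 `COC(=O)c1cc(-c2ccc(F)nc2F)nn(Cc2ccc(Cl)cc2)c1=O` and compound 3 `O=C(O)c1cc(-c2ccc(F)nc2F)nn(Cc2ccc(Cl)cc2)c1=O` share one core; compound 2 `COC(=O)CCNc1nc(F)c(-c2nn(Cc3ccc(C#N)cc3)c(=O)c3ccccc23)cc1Cl` and compound 4 `N#Cc1ccc(Cn2nc(-c3cc(Cl)c(NCCC(=O)O)nc3F)c3ccccc3c2=O)cc1` share another, and the difference between the two cores is not broken down here. In an ADME assay on HepG2 2.2.15 cells (Homo sapiens) for cytotoxicity, read by MTT assay, with a stated time of 8 days (a higher number here means that more compound is tolerated, a lower number that less compound is tolerated), compound 1 gives only a limit, > 100000 nM. In this assay compound 3 likewise gives only a limit, > 100000 nM. The change between them is hydrogen in place of methyl on an oxygen next to a carbonyl group, and the step that the two limits leave unreadable from compound 1 to compound 3 stays unreadable because of the limit of > 100000 nM in this assay, at which 3 of the 3 values shown sit. In this assay compound 2 gives only a limit, > 100000 nM. Compound 4 carries the same change, (hydrogen in place of methyl on an oxygen next to a carbonyl group). For compound 4 the step that the limit leaves unreadable from compound 2 to compound 4 is expected to be negligible, an expectation that rests on (the limit of > 100000 nM in this assay, at which 3 of the 3 values shown sit). Compound 4 is estimated at 150000 nM, expected to lie between 60000 nM and 500000 nM, most likely reported only as a limit.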

Compound 4, half-maximal cytotoxic concentration: > 100000 nM
Compound 4 was reported as a limit (the forecaster's own chance of this, stated with the estimate: 85%); the middle value does not contradict the limit.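

In this assay the step between compound 2 and compound 4 cannot be read, as both values are limits: the limit of > 100000 nM in this assay, at which 4 of the 4 values shown sit.

The compounds shown leave open whether methoxycarbonyl to carboxy changes tolerance on either core.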